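Replacing iodo with methoxy in a growth-inhibitor pair

The source may report more compounds than this note shows. Statements on the series, on what has been measured and on what is new or still open speak of the compounds shown alone.

compound 1 `NC(=O)c1cc(Cl)ccc1NC(=O)COc1ccccc1`: 2580 nM
compound 2 `NC(=O)c1cc(I)ccc1NC(=O)COc1ccccc1`: 454 nM

For the measured compounds named here, in a functional assay on SW-620 cells (Homo sapiens) for inhibition (a lower number here means a stronger inhibitor of growth, a higher number a weaker inhibitor of growth), compound 2 has the lower of the two numbers so far, which makes it the stronger inhibitor. Compound 3 `COc1ccc(NC(=O)COc2ccccc2)c(C(N)=O)c1` carries methoxy in place of iodo on an aromatic carbon. Going by the values given here, one measured step bears on this spot, iodo in place of chloro, a 5.7-fold lower number from compound 1 to compound 2 (0.75 log units; beyond the scatter), and it lies beyond the scatter. Among the compounds with values here, no methoxy compound has been measured, so this guide is loose. With the iodo gone, a higher number is expected, a 4.0-fold higher number from compound 2 to compound 3 (0.60 log units; beyond the scatter). For compound 3 the estimated value is 1800 nM, with an expected range of 500 nM to 6000 nM.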

Compound 3, concentration for 50% growth inhibition: 448 nM
Compound 3: middle estimate off by 4.0-fold (0.60 log units), on the high side; measured number below the stated range.
By their numbers in this assay, from the lowest: compounds 3 and 2 (each within the scatter of the next); then compound 1.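

Swapping iodo for methoxy on this aromatic carbon gives a 1.0-fold lower number from compound 2 to compound 3 (0.01 log units; within the scatter) in this assay and so leaves no readable difference, which means iodo is not required for the lower number. Methoxy in place of chloro gives a 5.8-fold lower number from compound 1 to compound 3 (0.76 log units; beyond the scatter) and matches the gain seen with iodo, so two quite different groups both outdo chloro here. Nothing available explains why these groups give these numbers.

As far as these compounds go, whether an amine, a carboxylic acid or a longer chain such as ethoxy would hold the number this low at this position remains open.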